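Solubility notes on a fused core series: amino-pyrazole to biaryl

The source may hold more compounds than are shown below. What is called first, only, known or untested is meant among the compounds shown, and "the series" means these compounds.

Measured compounds:
compound 1, `CN(c1ccn(C)n1)c1cnc(NCc2c(F)ccc3c2CCO3)c2cn[nH]c(=O)c12`, 12000 nM
compound 2, `O=C1c2ccccc2CN1c1cnc(NCc2c(F)ccc3c2CCO3)n2cnnc12`, 4000 nM

The read-out throughout is a physicochemical assay for solubility, read by LC-MS, in phosphate buffer, with a stated time of 24 h, at pH 7.4; a higher number here means a more soluble compound, a lower number a less soluble compound. Of the two measured compounds, compound 1 gives the higher number and compound 2 gives the lower one; the gap between them lies beyond the scatter of repeat measurements. Compound 1 therefore stands at the top of the small set so far.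

Compound 3, `Cc1nn(C)cc1-c1cnc(NCc2c(F)ccc3c2CCO3)c2cn[nH]c(=O)c12`, has not yet been run in this assay. It differs from compound 1 in one place, with the change (1,3-dimethyl-1H-pyrazol-4-yl in place of methyl(1-methyl-1H-pyrazol-3-yl)amino on an aromatic carbon). The group that leaves carries one more hydrogen-bond acceptor than the group that enters, and the enters group is joined directly through the five-membered aromatic ring rather than through an amino link. Among the compounds with values here, no measured pair in the set carries this change, so the expectation rests on compound 1 alone.

The step in this assay from compound 1 to compound 3 is estimated as a 1.7-fold lower number from compound 1 to compound 3 (0.23 log units; within the scatter), a modest drop that may not exceed the scatter. Compound 3 is expected to give about 7000 nM, within 2500 nM to 25000 nM.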

Compound 3, solubility: 9000 nM
For compound 3 the middle estimate is 1.3-fold (0.11 log units) below the measured one; the measured number falls inside the stated range.
By their numbers in this assay, from the lowest: compound 2; then compounds 3 and 1 (each within the scatter of the next).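

At this position, on an aromatic carbon of a six-membered aromatic ring with 1 nitrogen, placing 1,3-dimethyl-1H-pyrazol-4-yl where methyl(1-methyl-1H-pyrazol-3-yl)amino stood gives in this assay a 1.3-fold lower number from compound 1 to compound 3 (0.12 log units; within the scatter) and this read-out does not separate the two compounds. Within the data shown here, this is the first pair in the set that differs in one place, and it shows that the amino link can give way to direct attachment of the five-membered aromatic ring with no step beyond the scatter. No measurement at hand bears on why the pair reads this way.

This single pair is all that speaks to the position, so it says nothing yet about other groups placed there, such as a morpholine, a primary amine or a carboxylic acid, or about a pyrazole carrying a longer chain in place of its methyl groups. On these data alone, compound 2 differs from compound 1 and compound 3 in more than one place, so whether the same change would read alike on the core of compound 2 also stays open.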